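Swapping a nitrile for a hydroxyl on the benzyl arm

This account rests on a few compounds, and the source may have more. Where it says the series, first, only, none or still open, it means among the compounds named here.

Three compounds share a core and differ in the group on the benzyl arm. Compound 1 `c1ccc(Cn2cncc2-c2cc3ccccc3[nH]2)cc1` carries a plain phenyl there; in an assay on isolated protein for inhibition of Indoleamine 2,3-dioxygenase 1 (Homo sapiens), with a stated time of 1 h (on this read-out higher numbers stand for weaker inhibition and lower numbers for stronger inhibition), compound 1 gives 34800 nM. Compound 2 `Brc1ccc2[nH]c(-c3cncn3Cc3ccc(-c4ccccc4)cc3)cc2c1` adds a bromine to the core and a second phenyl to the arm; in this assay compound 2 gives 34200 nM. Compound 3 `N#Cc1ccc(Cn2cncc2-c2cc3cc(Br)ccc3[nH]2)cc1` keeps that bromine but has a cyano on the arm, and compound 3 gives 3810 nM, the lowest of the three numbers. Within the data shown here, the one step measured at this position, a 9.0-fold lower number from compound 2 to compound 3 (0.95 log units; beyond the scatter), shows the gain brought by the cyano.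

Compound 4 `Oc1cccc(Cn2cncc2-c2cc3cc(Br)ccc3[nH]2)c1` is the next step: 3-hydroxyphenyl in place of 4-cyanophenyl on a saturated chain carbon bound to an aromatic nitrogen. Among the measured compounds shown here, no measured pair shows what a hydroxyl does on this arm, so the step from compound 2 to compound 3 is only an indirect guide: it shows that the arm's group matters, not which way a hydroxyl will move the number. The expectation is therefore a modest rise in number, with the cyano's gain partly given back. For compound 4 the estimated step is a 2.6-fold higher number from compound 3 to compound 4 (0.42 log units; beyond the scatter). For compound 4 the expected value in this assay is 10000 nM, within a range from 3000 nM to 40000 nM.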

Compound 4, half-maximal inhibitory concentration: 1600 nM
Compound 4: the middle estimate sits 6.3-fold (0.80 log units) above what was measured, outside the stated range (below it).
By their numbers in this assay, from the lowest: compound 4; then compound 3; then compounds 2 and 1 (each within the scatter of the next).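

Replacing the 4-cyanophenyl with 3-hydroxyphenyl on a saturated chain carbon bound to an aromatic nitrogen gives a 2.4-fold lower number from compound 3 to compound 4 (0.38 log units; beyond the scatter) in this assay, so the nitrile is not needed for the gain seen earlier at this position, and a group without it can do better. Together with a 9.0-fold lower number from compound 2 to compound 3 (0.95 log units; beyond the scatter), this makes two steps beyond the scatter on the same bromine-bearing core, and both show that the number follows the group on the benzyl arm, with the entering group also bringing a hydrogen-bond donor that the 4-cyanophenyl lacks. No measurement shown here explains what lies behind the drop, so neither the donor nor any other feature of the hydroxyl can be credited with it.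

The swap changes both the group and its number on the ring, so a 4-hydroxyphenyl arm would be needed to tell these two changes apart. Going by these compounds, whether the hydroxyl itself matters also stays open, and a 3-methoxyphenyl or 3-aminophenyl arm on the same core would bear directly on that question.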